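The source may hold more compounds than are shown below. What is called first, only, known or untested is meant among the compounds shown, and "the series" means these compounds.

Measured so far:
compound 1, `Oc1ccc(-c2cc(-c3cccs3)cc(-c3cccc(O)c3)n2)cc1`, with 85.7%;
compound 2, `Oc1cccc(-c2cc(-c3ccoc3)cc(-c3ccccc3O)n2)c1`, with 29.5%.

In an assay on isolated protein for inhibition of DNA topoisomerase 1 (Homo sapiens), with a stated time of 30 min, tested at 100 uM (a lower number here means a weaker effect, a higher number a stronger effect of the compound at the concentration tested), compound 2 gives 29.5%, the lower of the two numbers shown. Compound 1 gives 85.7%, a gap beyond the usual scatter. Compound 1 and compound 2 differ at more than one place, so the two numbers alone do not tell what each difference contributes.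

Compound 3, `Oc1ccc(-c2cc(-c3ccoc3)cc(-c3cccc(O)c3)n2)cc1`, has not yet been measured in this assay. It differs from compound 2 in one place: 4-hydroxyphenyl in place of 2-hydroxyphenyl on an aromatic carbon. In this respect compound 3 matches compound 1, while it keeps the furan-3-yl group of compound 2. Within the data shown here, no step between measured compounds that differ in only one place is known, so the size of this change is open. Compound 3 is expected to sit above compound 2 in this assay because compound 1 with the same 4-hydroxyphenyl group gives 85.7%. The step of a number 25.5 percentage points higher from compound 2 to compound 3 (beyond the scatter) that this estimate means is expected to be upward and beyond the scatter. For compound 3 the estimate is 55%, within 25% to 85%.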

Compound 3, a percentage reported as inhibition, at one concentration (the size of the read-out at that concentration, not a potency): 37.4%
The estimate for compound 3 lay 17.6 percentage points above the measured number; the range from low to high includes it.
By their numbers in this assay, from the lowest: compounds 2 and 3 (each within the scatter of the next); then compound 1.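

In this assay, 4-hydroxyphenyl in place of 2-hydroxyphenyl on an aromatic carbon next to the ring nitrogen gives a number 7.9 percentage points higher from compound 2 to compound 3 (within the scatter), so with furan-3-yl on the core this exchange of hydroxyphenyl groups does not separate the two compounds. By contrast, furan-3-yl in place of thiophen-2-yl on an aromatic carbon gives a number 48.3 percentage points lower from compound 1 to compound 3 (beyond the scatter), so of the two single changes now readable, only this one exceeds the scatter, and it is large. No measurement is available that explains either step.

The compounds shown leave open whether the exchange of 2-hydroxyphenyl for 4-hydroxyphenyl would also stay within the scatter with thiophen-2-yl on the core, as the only reading of it comes from a furan-3-yl compound. They also do not separate the ring's heteroatom from its point of attachment, which thiophen-3-yl and furan-2-yl groups would address, and they do not show how a plain phenyl or an aminophenyl group would read at either place.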